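Aryl ketone swap on the carbonyl carbon toward compound 4

The compounds below may be only part of what the source reports. "The series", "measured", "known", "first", "only" and "open" are said of these compounds alone.

Compound 1 `COc1cc(-c2nnc3n2NC(c2cccs2)C(C(=O)c2ccc(C)cc2)S3)cc(OC)c1OC`: 28400 nM
Compound 2 `COc1cc(-c2nnc3n2NC(c2ccco2)C(C(=O)c2ccc(C)cc2)S3)cc(OC)c1OC`: > 100000 nM (a limit)
Compound 3 `COc1cc(C(=O)C2Sc3nnc(-c4cc(OC)c(OC)c(OC)c4)n3NC2c2cccs2)cc(OC)c1OC`: 71000 nM

In a functional assay on MCF7 cells (Homo sapiens) for cytotoxicity, read by MTT assay, with a stated time of 48 h (a lower number here means a stronger inhibitor, a higher number a weaker inhibitor), compound 1 gives 28400 nM. Compound 3 gives 71000 nM. For compound 2 the assay reports only a limit, > 100000 nM. The measured steps are an at least 3.5-fold higher number from compound 1 to compound 2 (0.54 log units; beyond the scatter) and a 2.5-fold higher number from compound 1 to compound 3 (0.40 log units; beyond the scatter). Compound 2 therefore stands at the weak end of the three, one of the values sitting at the limit of > 100000 nM in this assay, at which 1 of the 3 values shown sits.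

Compound 4 `COc1cc(-c2nnc3n2NC(c2ccco2)C(C(=O)c2cccc4ccccc24)S3)cc(OC)c1OC` differs from compound 2 by naphthalen-1-yl in place of 4-methylphenyl on a carbonyl carbon. For the measured compounds named here, the only measured change on that carbonyl carbon is a 2.5-fold higher number from compound 1 to compound 3 (0.40 log units; beyond the scatter), modest and toward weaker inhibition; no step with naphthalen-1-yl has been measured. With compound 2 already at a limit, compound 4 is expected at 150000 nM, in a range from 40000 nM to 500000 nM. This is expected to correspond to a step that the limit leaves unreadable from compound 2 to compound 4, most likely again reported only as a limit.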

Compound 4, half-maximal inhibitory concentration: > 100000 nM
Compound 4 gave a limit, no number; the forecaster's own chance of this, stated with the estimate: 70%; the middle value does not contradict the limit.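

Compound 2 and compound 4 both sit at a limit, so no step between them can be read: the limit of > 100000 nM in this assay, at which 2 of the 4 values shown sit.

The compounds shown leave open how naphthalen-1-yl compares with 4-methylphenyl on a carbonyl carbon.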